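Methoxy addition on two cores: a sulforhodamine growth read-out

The source may report more compounds than this note shows. Statements on the series, on what has been measured and on what is new or still open speak of the compounds shown alone.

Compound 1 `O=c1ccoc(/C=C/c2ccccc2)c1` and compound 2 `COc1ccc(/C=C/c2cc(=O)cco2)cc1` share one core, while compound 3 `COc1ccc(/C=C/C2CC=CC(=O)O2)cc1OC` and compound 4 `COc1cc(OC)c(OC)cc1/C=C/C1CC=CC(=O)O1` share another; the difference between the two cores is not broken down here. In a functional assay on HT-29 cells (Homo sapiens) for inhibition, read by sulforhodamine B assay, with a stated time of 48 h (on this read-out lower numbers stand for stronger inhibition of growth and higher numbers for weaker inhibition of growth), compound 1 gives 344 uM, and compound 2 gives 379 uM. The change between them is methoxy in place of hydrogen on an aromatic carbon and amounts to a 1.1-fold higher number from compound 1 to compound 2 (0.04 log units; within the scatter). Compound 3 gives 17.2 uM in this assay, which sets it apart from compound 1 and compound 2 by steps beyond the scatter.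

Compound 4 is not yet measured. It differs from compound 3 by methoxy in place of hydrogen on an aromatic carbon. This is the same kind of change as from compound 1 to compound 2, though the place is not the same: in compound 2 the new methoxy sits para to a group of 9 heavy atoms, whereas in compound 4 it sits ortho to a group of 9 heavy atoms, meta to a methoxy group and para to a methoxy group. Going by the values given here, because the only measured step of this kind, a 1.1-fold higher number from compound 1 to compound 2 (0.04 log units; within the scatter), stays within the scatter, the step from compound 3 to compound 4 is expected to be similar, estimated at a 1.1-fold higher number from compound 3 to compound 4 (0.04 log units; within the scatter). Compound 4 is therefore expected to give about 19 uM in this assay, with the estimate spanning 8 uM to 45 uM.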

Compound 4, concentration for growth inhibition (reported as GI): 15.9 uM
Estimate against measurement, compound 4: 1.2-fold (0.08 log units) above; measured number inside the range.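

In this assay, methoxy in place of hydrogen on the core of compound 3 gives a 1.1-fold lower number from compound 3 to compound 4 (0.03 log units; within the scatter) and adds a second case in which this change produces no step beyond the scatter. Set beside the earlier step, the result on this core does not differ from that on the core of compound 1: the same change on two cores in this assay, a 1.1-fold higher number (0.04 log units; within the scatter) from compound 1 to compound 2 and a 1.1-fold lower number (0.03 log units; within the scatter) from compound 3 to compound 4, 1.2-fold (0.08 log units) apart, within the scatter of two such steps. This shows only that, in these two pairs, the change leaves the growth read-out within the scatter on both cores; it does not show that the same would hold for every place on the aromatic ring or on any other core, as the new methoxy does not stand in the same place in the two pairs, the ring of compound 3 already carries methoxy groups, and the effects of core and place cannot be separated.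

Going by these compounds, the aromatic ring changes here only from hydrogen to methoxy, so it remains open what an amine, a carboxylic acid or a longer chain such as butoxy would do in that place on either core. The two cores also remain unlinked by any single-place change, which leaves open what separates their numbers in this assay.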